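One Drawn Stereocentre, Compound 3 to Compound 4

The source may report more compounds than this note shows. Statements on the series, on what has been measured and on what is new or still open speak of the compounds shown alone.

In a functional assay on BXPC-3 cells (Homo sapiens) for inhibition, read by MTT assay, with a stated time of 7 days (a higher number here means a weaker inhibitor, a lower number a stronger inhibitor), compound 1 `CCN1CC(NC(=O)[C@@H]2CCCN(S(=O)(=O)c3ccc(S(=O)(=O)N(CC)CC)cc3)C2)C1` gives only a limit, > 30000 nM. Compound 2 `CCN(CC)S(=O)(=O)c1ccc(S(=O)(=O)N2CCC[C@@H](C(=O)NC3COC3)C2)cc1` gives 13800 nM, and compound 3 `CCOC(=O)[C@@H]1C[C@@H](O)CN(S(=O)(=O)c2ccc(S(=O)(=O)N(CC)CC)cc2)C1` gives 10800 nM. These two numbers lie within the scatter of each other, so they cannot be ranked, and compound 3 sits level with compound 2 in this small set.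

Compound 4 `CCOC(=O)[C@@H]1C[C@H](O)CN(S(=O)(=O)c2ccc(S(=O)(=O)N(CC)CC)cc2)C1` is the next case, and it keeps every atom and bond of compound 3: the two compounds have the same atoms and bonds and differ only in configuration as drawn: 1 of 2 stereo elements differ; a stereocentre at a saturated ring carbon is drawn R in compound 3 and S in compound 4. Only the configuration as drawn differs.

Just one measured step is available, an at least 2.1-fold lower number from compound 1 to compound 2 (0.33 log units; beyond the scatter), and it starts from the limit of > 30000 nM in this assay, at which 1 of the 3 values shown sits. That step swaps a group on an amide-type nitrogen, a change of a different kind from the one here. Among the measured compounds shown here, no measured pair differs in configuration alone, so the data do not show how much such a change matters.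

The expectation therefore stays anchored on compound 3 at 10800 nM, with no step beyond the scatter expected in this assay, and with a wide margin in either direction. The expected change is a 1.0-fold higher number from compound 3 to compound 4 (0.01 log units; within the scatter). For compound 4 the estimated value is 11000 nM, within an expected range of 5000 nM to 25000 nM.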

Compound 4, half-maximal inhibitory concentration: 3300 nM
Estimate against measurement, compound 4: 3.3-fold (0.52 log units) above, outside the stated range (below it).
By their numbers in this assay, from the lowest: compound 4; then compounds 3 and 2 (each within the scatter of the next). At a limit, above all of these: compound 1.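

The earlier compounds shown here held no pair that differed in configuration alone, and this pair gives the first reading: in this assay there is a 3.3-fold lower number from compound 3 to compound 4 (0.51 log units; beyond the scatter) with no atom or bond changed. Drawing one saturated ring carbon as S rather than R is therefore enough, for this pair, to move the number beyond the usual scatter, so configuration at this position cannot be treated as a detail of the drawing. The step can be tied to that single stereocentre because nothing else separates the two structures: the fact that compounds 3 and 4 differ only in the configuration as drawn.

What the compounds shown leave open is whether the other stereo element matters to a similar degree, since it is drawn the same in both compounds and only one of the possible arrangements of the two centres is compared here. As far as these compounds go, it is also open whether the preference for S at this carbon would hold if the ethyl ester gave way to a carboxylic acid or a primary amide, or whether it belongs to this one pair alone.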